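A few compounds are considered here, and "the series" means these few. Any claim that something is new, unique, unknown or untested is made for them only; others in the source may bear on it.

Measured compounds in a functional assay on CHO cells for positive allosteric modulation of muscarinic acetylcholine receptor M5 (Homo sapiens), read by FLIPR and calcium flux, with a stated time of 1 h; a lower number here means a smaller maximal response, a higher number a larger maximal response:
- compound 1, `O=C1C(=O)N(Cc2ccc(-c3cccnc3)cc2)c2ccc(OC(F)(F)F)cc21`, gives 51%
- compound 2, `O=C1C(=O)N(Cc2ccc(-c3ccccc3)cn2)c2ccc(OC(F)(F)F)cc21`, gives 47%
- compound 3, `O=C1C(=O)N(Cc2ccc(-c3ccccc3)nc2)c2ccc(OC(F)(F)F)cc21`, gives 76%

Among these three numbers compound 1 stands second highest. Its nearest neighbour is compound 2, whose value lies lower but within the scatter, so no order between compound 1 and compound 2 can be read from the data. The furthest is compound 3, whose value lies higher and beyond the scatter; of the two compounds bearing the phenyl-substituted heteroaromatic ring on the benzylic position, compound 3 is the one that separates itself clearly.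

The next compound, compound 4, `O=C1C(=O)N(Cc2ccc(-c3cncnc3)cc2)c2ccc(OC(F)(F)F)cc21`, differs from compound 1 in one place: pyrimidin-5-yl in place of pyridin-3-yl on an aromatic carbon. Among the compounds with values here, no pair of measured compounds in this assay shares this change, so the size of the step cannot be taken from a measured comparison. On the evidence available, the step from compound 1 to compound 4 is expected to stay within the scatter, a number 3 percentage points lower from compound 1 to compound 4 (within the scatter), with no direction that can be called beyond it. Compound 4 is therefore expected to give 48% in this assay, with a range from 30% to 68%.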

Compound 4, largest response reached (Emax), in percent of the reference or control that the assay uses: 53%
For compound 4 the middle estimate is 5 percentage points below the measured one; the measured number falls inside the stated range.
By their numbers in this assay, from the lowest: compounds 2, 1 and 4 (each within the scatter of the next); then compound 3.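

In this assay pyrimidin-5-yl in place of pyridin-3-yl, para to a large group, gives a number 2 percentage points higher from compound 1 to compound 4 (within the scatter), so this position accepts a second hetero atom in the aromatic ring, and one more hydrogen-bond acceptor by count, with no readable change in maximal response. Within the data shown here, this is the only step so far between compounds that differ in one place, and it gives this position its first measured comparison. No measurement bearing on the reason for this result is available.

Open, from the compounds shown here alone, is how the maximal response answers at this position to a morpholine, a primary amine or a carboxylic acid in place of the pyrimidin-5-yl. A single step within the scatter also leaves open whether the number of ring nitrogens matters here at all.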